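The source may hold more compounds than are shown below. What is called first, only, known or untested is meant among the compounds shown, and "the series" means these compounds.

Measured compounds in a functional assay on SMMC-7721 cells (Homo sapiens) for cytotoxicity, read by MTT assay, with a stated time of 24 h; a higher number here means a weaker inhibitor, a lower number a stronger inhibitor:
compound 1, `O=C1/C(=C/c2cccc(F)c2)CN(S(=O)(=O)c2ccc(F)cc2)C/C1=C\c1cccc(F)c1`, gives 13500 nM
compound 2, `N#Cc1ccc(S(=O)(=O)N2C/C(=C\c3cccc(F)c3)C(=O)/C(=C/c3cccc(F)c3)C2)cc1`, gives 4500 nM
compound 3, `O=C1/C(=C/c2ccc(F)cc2)CN(S(=O)(=O)c2ccccc2)C/C1=C\c1ccc(F)cc1`, gives 9100 nM

Compound 3 stands second highest of the three numbers; its gap to compound 1 lies within the scatter, its gap to compound 2 beyond it. Not yet measured is compound 4, `O=C1/C(=C/c2ccc(F)cc2)CN(S(=O)(=O)c2ccc(O[N+](=O)[O-])cc2)C/C1=C\c1ccc(F)cc1`. The change from compound 3 to compound 4 is nitrooxy in place of hydrogen on an aromatic carbon. Among the compounds with values here, one measured step bears on it, an exchange of the group on the same sulfonyl-bearing aromatic ring: a 3.0-fold lower number from compound 1 to compound 2 (0.48 log units; beyond the scatter). Within the data shown here, that single step gave a lower number when the group on that ring was exchanged, but no measured pair carries the nitrooxy group, and compound 3 and compound 4 differ from compound 1 and compound 2 in the fluoro pattern on the other two rings, so the carry-over is uncertain. A modest lowering is therefore expected, a 1.7-fold lower number from compound 3 to compound 4 (0.22 log units; within the scatter), with a wide range. For compound 4 the estimate in this assay is 5500 nM, expected to fall between 2000 nM and 15000 nM.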

Compound 4, half-maximal inhibitory concentration: 5000 nM
The estimate for compound 4 lay 1.1-fold (0.04 log units) above the measured number; low and high end bracket the measured number.
By their numbers in this assay, from the lowest: compounds 2, 4, 3 and 1 (each within the scatter of the next, the first and the last beyond it).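

In this assay, within the data shown here, phenyl to 4-(nitrooxy)phenyl gives a 1.8-fold lower number from compound 3 to compound 4 (0.26 log units; within the scatter), the first reading of a hydrogen replaced on the aromatic carbon para to a large group. This step stays within the scatter, so the sulfonyl-bearing ring takes the added nitrooxy group with no clear shift in the number, whereas the exchange of fluoro for cyano on the other fluoro pattern, a 3.0-fold lower number from compound 1 to compound 2 (0.48 log units; beyond the scatter), lay beyond it. Nothing available explains either step or ties it to a property of the group.

From the compounds shown here alone, whether a much smaller substituent, such as a methyl group, or a charged one, such as a carboxylic acid or an amine, would read the same at this place remains open. Also open, going by these compounds, is whether the nitrooxy group would behave alike on the fluoro pattern of compound 1.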